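The source may report more compounds than this note shows. Statements on the series, on what has been measured and on what is new or still open speak of the compounds shown alone.

Compound 1 `COc1ccccc1/C=C/C(=O)c1ccc(OCC(=O)N[C@H]2CCOC2=O)cc1` gives 7240 nM in a functional assay on PC-3 cells (Homo sapiens) for antiproliferative activity, read by MTT assay, with a stated time of 72 h; on this read-out lower numbers stand for stronger inhibition and higher numbers for weaker inhibition.
Compound 2 `O=C(COc1ccc(C(=O)/C=C/c2cccc(Br)c2)cc1)N[C@H]1CCOC1=O` gives 7890 nM in this assay.
Compound 3 `O=C(CNc1ccc(Cl)cc1Cl)N[C@H]1CCOC1=O` reaches only a limit of this assay, > 64000 nM.

Among the two numbers, compound 2 carries the one that is not lower, but its nearest neighbour is compound 1, and the step of a 1.1-fold higher number from compound 1 to compound 2 (0.04 log units; within the scatter) lies within the scatter, so the two cannot be ranked. The third value is the limit (the limit of > 64000 nM in this assay, at which 1 of the 3 values shown sits), recorded for compound 3 alone and not a number.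

Compound 4 `O=C(COc1ccc(C(=O)/C=C/c2cccc(F)c2)cc1)N[C@H]1CCOC1=O` has not yet been measured in this assay. It differs from compound 2 by fluoro in place of bromo on an aromatic carbon. Among the compounds with values here, the only measured step that touches this part of the molecule is the one from compound 1 to compound 2, which exchanged one ring substituent for another and moved the number by a 1.1-fold higher number from compound 1 to compound 2 (0.04 log units; within the scatter). That step gives no sign that the substituent on this ring shifts the read-out beyond the scatter, and the present exchange of one halogen for another is smaller still in kind.

The step of a 1.1-fold higher number from compound 2 to compound 4 (0.06 log units; within the scatter) is therefore expected to stay within the scatter. Compound 4 is estimated at 9000 nM in this assay, with a range from 4000 nM to 20000 nM.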

Compound 4, half-maximal inhibitory concentration: 23200 nM
Beside the measured number, compound 4's estimate is 2.6-fold (0.41 log units) below it; the measured number lies above the stated range.
By their numbers in this assay, from the lowest: compounds 1 and 2 (each within the scatter of the next); then compound 4. At a limit, above all of these: compound 3.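

In this assay the exchange of fluoro for bromo on this aromatic carbon gives a 2.9-fold higher number from compound 2 to compound 4 (0.47 log units; beyond the scatter), a modest step but the first one at this ring to lie beyond the scatter. The earlier pair had suggested that the ring substituent made little difference, since 3-bromophenyl in place of 2-methoxyphenyl gave only a 1.1-fold higher number from compound 1 to compound 2 (0.04 log units; within the scatter), yet the 3-fluorophenyl group separates from the 2-methoxyphenyl group as well, with a 3.2-fold higher number from compound 1 to compound 4 (0.51 log units; beyond the scatter). This position therefore does respond to a change of substituent, and a swap of one halogen for another is enough to weaken the inhibition, leaving compound 4 the weakest of compounds 1, 2 and 4 on this read-out. Nothing measured here bears on why the fluoro compound falls behind the bromo compound.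

From the compounds shown here alone, what a chloro group, a methyl group or a plain hydrogen would give at this same place stays open, so the two halogens do not yet define a trend. Going by these compounds, it is also open whether a fluoro group on another carbon of this ring, or an amine in its place, would move the number in the same direction.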